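A few compounds are considered here, and "the series" means these few. Any claim that something is new, unique, unknown or untested is made for them only; others in the source may bear on it.

Measured so far in a functional assay on MCF7 cells (Homo sapiens) for cytotoxicity, read by MTT assay, with a stated time of 72 h; a lower number here means that less compound is tolerated, a higher number that more compound is tolerated:
Compound 1 `CSc1ccc(CNc2nc(SC)nc3ncccc23)cc1` gives 9130 nM.
Compound 3 `CSc1nc(NCCCCc2ccccc2)c2ccccc2n1` gives 95900 nM.
Compound 2 `CSc1nc(NCCCCCO)c2ccccc2n1` gives > 100000 nM, which is a limit of this assay and not a number (the limit of > 100000 nM in this assay, at which 1 of the 3 values shown sits).

Compound 1 therefore shows the lower of the two numbers in this assay, and its gap to compound 3 lies beyond the scatter. Compound 4 `CSc1nc(NCc2ccccc2)c2cccnc2n1` keeps the core and the aminomethyl link of compound 1 and differs by hydrogen in place of methylsulfanyl on an aromatic carbon. For the measured compounds named here, only one measured step exists, an at least 1.0-fold lower number from compound 2 to compound 3 (0.01 log units; that floor lies within the scatter), and it concerns a different core and a change far out on a saturated chain; it lies within the scatter. Going by the values given here, no measured step removes a methylsulfanyl from an aromatic ring, so the account rests on the small size of the one step seen. Compound 4 is expected to move by a 1.6-fold higher number from compound 1 to compound 4 (0.22 log units; within the scatter), a shift within the scatter, if at all. Compound 4 is thus estimated at 15000 nM, with a range from 5000 nM to 60000 nM.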

Compound 4, concentration lethal to 50% of the cells: > 100000 nM
Compound 4: no number, only a limit; the forecaster's own chance of this, stated with the estimate: 10%; middle value at least 6.6-fold (0.82 log units) from the limit.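

Replacing methylsulfanyl with hydrogen on an aromatic carbon, para to a large group, gives an at least 10-fold higher number from compound 1 to compound 4 (1.03 log units; beyond the scatter) in this assay. This is the first single change among these compounds that lies beyond the scatter, whereas the only earlier step, made far out on a saturated chain of a different core, lay within it. Compound 4 stands at a limit of the assay and not at a number, so the printed size of the step is only a floor: the limit of > 100000 nM in this assay, at which 2 of the 4 values shown sit.

As far as these compounds go, how far compound 4 lies past that limit stays open. Whether a methoxy group, a methyl group or a chlorine atom at this same place would behave like methylsulfanyl or like hydrogen also cannot be told from the compounds shown.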